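The source may report more compounds than this note shows. Statements on the series, on what has been measured and on what is new or still open speak of the compounds shown alone.

Compound 1 `COc1ccc(C(=O)c2cc(/C=C/C(=O)NO)n(C)c2)cc1`: 75.2%
Compound 2 `Cn1cc(C(=O)c2ccccc2)cc1/C=C/C(=O)NCCO`: 0.9%
Compound 3 `Cn1cc(C(=O)c2ccccc2)cc1CCC(=O)NO`: 45%

In an assay on isolated protein for inhibition of histone deacetylase HD2 (Zea mays), tested at 30 uM (on this read-out higher numbers stand for more inhibition at the one concentration tested (going by the name of the read-out) and lower numbers for less inhibition), compound 1 stands highest of the three numbers. Compound 3 comes nearest, lower by an amount beyond the usual scatter, and compound 2 lies lowest, also beyond the scatter. Compound 4 `CN(C)c1ccc(C(=O)c2cc(/C=C/C(=O)NO)n(C)c2)cc1` has not been measured yet. It differs from compound 1 in one place: dimethylamino in place of methoxy on an aromatic carbon. Among the measured compounds shown here, no two measured compounds differ in only one place, so no step of this kind has been seen here. The exchange of methoxy for dimethylamino on an aromatic carbon leaves the rest of compound 1 untouched, so only a small step in this assay is expected, with no clear direction and probably within the scatter. The expected step from compound 1 to compound 4 is a number 3.2 percentage points lower from compound 1 to compound 4 (within the scatter). Compound 4 is therefore estimated at 72%, in a range from 50% to 90%.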

Compound 4, a percentage reported as inhibition, at one concentration (the size of the read-out at that concentration, not a potency): 88%
For compound 4 the middle estimate is 16 percentage points below the measured one; measured number inside the range.
By their numbers in this assay, from the lowest: compound 2; then compound 3; then compound 1; then compound 4.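

In this assay dimethylamino in place of methoxy, para to a large group, gives a number 12.8 percentage points higher from compound 1 to compound 4 (beyond the scatter) and so shows that this position responds to what sits on it. This is the first change in one place that can be read among these compounds, and it shows that the methoxy group can be exchanged here without losing inhibition. Nothing available says why the number rises. As far as these compounds go, it remains open whether a plain amine or a carboxylic acid at this position would hold the same level. From the compounds shown here alone, it is also open whether this gain would carry over to the other compounds, whose chains differ.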